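Fluorine joins chlorine on the carbonyl-bound ring of compound 1

The compounds below may be only part of what the source reports. "The series", "measured", "known", "first", "only" and "open" are said of these compounds alone.

Compound 1 `Cc1ccc2[nH]c(=O)c(CN(Cc3ccco3)C(=O)c3ccc(Cl)cc3)cc2c1` was examined in an ADME assay on MT2 cells (Homo sapiens) for cytotoxicity, read by XTT assay, with a stated time of 4 days; a lower number here means that less compound is tolerated, a higher number that more compound is tolerated. In this assay compound 1 gives > 61400 nM, which is a limit of the assay rather than a number. Compound 2 `Cc1ccc2[nH]c(=O)c(CN(Cc3ccco3)C(=O)c3ccc(Cl)c(N4CCCCC4)c3)cc2c1` carries piperidin-1-yl in place of hydrogen on an aromatic carbon relative to compound 1. In this assay compound 2 gives > 20400 nM, again a limit and not a number. The step that the two limits leave unreadable from compound 1 to compound 2 therefore cannot be read: both of its ends are limits, one at the limit of > 20400 nM in this assay, at which 1 of the 2 values shown sits, and one at the limit of > 61400 nM in this assay, at which 1 of the 2 values shown sits.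

Compound 3 `Cc1ccc2[nH]c(=O)c(CN(Cc3ccco3)C(=O)c3ccc(F)c(Cl)c3)cc2c1` differs from compound 1 as follows: 3-chloro-4-fluorophenyl in place of 4-chlorophenyl on a carbonyl carbon. Among the compounds with values here, no measured step shares this change, and the one step at hand is unreadable, so it offers no size to carry over. Compound 1 itself stands only at a limit in this assay. On this basis no step beyond the scatter is expected, and a limit is again the most likely outcome. Compound 3 is expected to give about 60000 nM in this assay, within 20000 nM to 150000 nM. The expected step of an at least 1.0-fold lower number from compound 1 to compound 3 (0.01 log units; that floor lies within the scatter) is thus estimated as none beyond the scatter.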

Compound 3, half-maximal cytotoxic concentration: > 23500 nM
Compound 3 was reported as a limit; the forecaster's own chance of this, stated with the estimate: 85%; the middle value does not contradict the limit.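

In this assay compound 3 gives > 23500 nM, a limit and not a number. Within the data shown here, compound 1 also stands only at a limit, so no step from compound 1 to compound 3 can be read. The compounds shown leave open at what concentration compound 1, compound 2 or compound 3 reaches half-maximal cytotoxicity, and whether either change alters it.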